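The source may hold more compounds than are shown below. What is called first, only, known or untested is meant among the compounds shown, and "the series" means these compounds.

Compound 1 `CCCCCC[S+]([O-])CC(O)(O)C(F)(F)F`: 79400 nM
Compound 2 `CCCCCCCC[S+]([O-])CC(O)(O)C(F)(F)F`: 14800 nM
Compound 3 `CCCCCCS(=O)(=O)CC(O)(O)C(F)(F)F`: 9770 nM

All three numbers come from an assay on isolated protein for inhibition of liver carboxylesterase 1 (Homo sapiens), with a stated time of 5 min; on this read-out higher numbers stand for weaker inhibition and lower numbers for stronger inhibition. Compound 2 lies between the other two: its value is within the scatter of that of compound 3, but beyond the scatter from compound 1. Compound 4 `CCCCCCCCCC[S+]([O-])CC(O)(O)C(F)(F)F` has not yet been measured; it differs from compound 2 by ethyl in place of hydrogen on a saturated chain carbon, eight bonds along the chain from a sulfur. For the measured compounds named here, the one measured step that bears on this is a 5.4-fold lower number from compound 1 to compound 2 (0.73 log units; beyond the scatter), the same kind of chain lengthening made one position earlier. On that basis a further lowering is expected in this assay, though probably smaller, as a 3.0-fold lower number from compound 2 to compound 4 (0.47 log units; beyond the scatter). Compound 4 is therefore estimated to give 5000 nM, expected to fall between 1500 nM and 15000 nM.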

Compound 4, inhibition constant: 5250 nM
Compound 4: middle estimate off by 1.1-fold (0.02 log units), on the low side; the measured number falls inside the stated range.
By their numbers in this assay, from the lowest: compounds 4, 3 and 2 (each within the scatter of the next, the first and the last beyond it); then compound 1.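

In this assay, adding a second ethyl further along the chain again lowers the number, giving a 2.8-fold lower number from compound 2 to compound 4 (0.45 log units; beyond the scatter). The effect of lengthening therefore does not stop at the first ethyl added to the chain of compound 1. Taken together, the butyl change amounts to a 15-fold lower number from compound 1 to compound 4 (1.18 log units; beyond the scatter), which makes chain length a strong lever at this position across these three compounds, although nothing given here explains the trend. Still open, going by these compounds, is whether a longer chain would lower the number further or reverse the trend, and whether a phenyl ring at the chain end could take the chain's place.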